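Compound 3 to compound 4: opening the cyclopentenyl ring

This account rests on a few compounds, and the source may have more. Where it says the series, first, only, none or still open, it means among the compounds named here.

In an ADME assay on Huh-7 cells (Homo sapiens) for cytotoxicity, with a stated time of 72 h (on this read-out higher numbers stand for lower toxicity in this test and lower numbers for higher toxicity in this test), compound 3 `CC(C)CCn1nc(C2=CCCC2)c(O)c(C2=NS(=O)(=O)c3cc(NS(C)(=O)=O)ccc3N2)c1=O` gives > 1000 nM, which is a limit and not a number. Compound 2 `CC(C)CCn1nc(C2CCCC2)c(O)c(C2=NS(=O)(=O)c3cc(NS(C)(=O)=O)ccc3N2)c1=O` gives > 1000 nM, also a limit. Compound 1 `CC(C)CCn1nc(-c2cncs2)c(O)c(C2=NS(=O)(=O)c3cc(NS(C)(=O)=O)ccc3N2)c1=O` gives > 33000 nM, again a limit.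

Compound 4 `CC(C)=Cc1nn(CCC(C)C)c(=O)c(C2=NS(=O)(=O)c3cc(NS(C)(=O)=O)ccc3N2)c1O` carries 2-methylprop-1-en-1-yl in place of the cyclopent-1-en-1-yl of compound 3, on the same aromatic carbon (2-methylprop-1-en-1-yl in place of cyclopent-1-en-1-yl on an aromatic carbon). The ring is lost, while the one double bond outside aromatic rings stays.

Within the data shown here, three measured steps bear on this change: a step that the two limits leave unreadable from compound 2 to compound 3, a step that the two limits leave unreadable from compound 1 to compound 3 and a step that the two limits leave unreadable from compound 1 to compound 2. None of them has a readable size, so they offer no direction. The closest is the step between the two cyclopentane-based groups, and it too gives only limits. No step beyond the scatter is therefore expected in this assay, in either direction, and another limit is the likely report.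

The expected change is a step that the limit leaves unreadable from compound 3 to compound 4. The estimated value for compound 4 is 10000 nM, with an expected range of 1000 nM to 50000 nM.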

Compound 4, half-maximal cytotoxic concentration: > 1000 nM
Compound 4: only a limit was reported (the forecaster's own chance of this, stated with the estimate: 90%); the middle value is on the limit's open side.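

Among these compounds, compound 4, like compound 1, compound 2 and compound 3, is reported only as a limit in this assay, so no step between compound 4 and any of the other three can be read. From the compounds shown here alone, whether the group on this aromatic carbon changes the half-maximal cytotoxic concentration stays open.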